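The compounds below may be only part of what the source reports. "The series", "measured", "known", "first", "only" and "open" are said of these compounds alone.

Compound 3 `Cc1noc(-c2ccccc2NCC2=NCCN2)n1` gives 661 nM in a functional assay for activation of Alpha-1A adrenergic receptor (Homo sapiens), read by calcium flux (a lower number here means that less compound is needed, a higher number that more compound is needed for the effect), the highest of the three numbers seen so far; compound 2 `Cc1ncc(-c2ccccc2NCC2=NCCN2)o1` gives 110 nM and compound 1 `c1coc(-c2ccccc2NCC2=NCCN2)c1` gives 0.468 nM. Compound 4 `c1ccc(-c2cnccn2)c(NCC2=NCCN2)c1` carries pyrazin-2-yl in place of 3-methyl-1,2,4-oxadiazol-5-yl on an aromatic carbon. Within the data shown here, no measured step exchanges a five-membered ring for a six-membered one, so the only guides are the ring swaps a 6.0-fold higher number from compound 2 to compound 3 (0.78 log units; beyond the scatter), a 240-fold higher number from compound 1 to compound 2 (2.37 log units; beyond the scatter) and a 1400-fold higher number from compound 1 to compound 3 (3.15 log units; beyond the scatter), each of which moved the number far. Because the smaller of these swaps a 6.0-fold higher number from compound 2 to compound 3 (0.78 log units; beyond the scatter) was modest, compound 4 is expected to move only modestly, a 4.4-fold lower number from compound 3 to compound 4 (0.64 log units; beyond the scatter), toward a lower number. Compound 4 is therefore estimated at 150 nM, with a wide range from 15 nM to 1500 nM.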

Compound 4, half-maximal effective concentration: 4.57 nM
Estimate against measurement, compound 4: 33-fold (1.52 log units) above; the whole stated range lies above it.
By their numbers in this assay, from the lowest: compound 1; then compound 4; then compound 2; then compound 3.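

Pyrazin-2-yl shows that a six-membered aromatic ring can stand at this place in this assay and still give a low number: it gives a 140-fold lower number from compound 3 to compound 4 (2.16 log units; beyond the scatter) and a 24-fold lower number from compound 2 to compound 4 (1.38 log units; beyond the scatter). The furan-2-yl group keeps the lowest number of the four, and the change to pyrazin-2-yl gives a 9.8-fold higher number from compound 1 to compound 4 (0.99 log units; beyond the scatter). Ring size alone therefore does not order these compounds. Nothing available accounts for these differences. On these data alone, how a pyridin-2-yl or phenyl group would behave at this place remains open.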